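Swapping a cyanophenyl for a methylphenyl on the sulfonyl

This account rests on a few compounds, and the source may have more. Where it says the series, first, only, none or still open, it means among the compounds named here.

Measured so far in an assay on isolated protein for displacement of a labelled ligand from metabotropic glutamate receptor 5 (Homo sapiens), with a stated time of 60 min, tested at 1 uM; a higher number here means more inhibition at the concentration tested (going by the name of the read-out), a lower number less inhibition:
compound 1 `Cc1cc(C)cc(S(=O)(=O)c2cnc3cc(F)ccc3c2N2CCC(C)CC2)c1` gives 80%
compound 2 `Cc1ccc(S(=O)(=O)c2cnc3cc(F)ccc3c2N2CCC(C)CC2)cc1C` gives 90%
compound 3 `CC1CCN(c2c(S(=O)(=O)c3cccc(C#N)c3)cnc3cc(F)ccc23)CC1` gives 92%

Compound 3 stands highest of the three numbers in this assay, though only its gap to compound 1 is beyond the scatter; compound 2 sits within the scatter of it.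

Compound 4 `Cc1ccc(S(=O)(=O)c2cnc3cc(F)ccc3c2N2CCC(C)CC2)cc1` differs from compound 3 at the sulfonyl sulfur only: 4-methylphenyl in place of 3-cyanophenyl on a sulfonyl sulfur

Among the compounds with values here, two steps bear on this change, since both replace a methyl-bearing phenyl with the 3-cyanophenyl. The step of a number 12 percentage points higher from compound 1 to compound 3 (beyond the scatter) is a modest gain, while the step of a number 2 percentage points higher from compound 2 to compound 3 (within the scatter) is within the scatter. Compound 4 reverses this direction, returning to a methyl-bearing phenyl, so a small drop in this assay is expected, probably within the scatter, with compound 1 setting the likely floor. The estimated step is a number 6 percentage points lower from compound 3 to compound 4 (within the scatter). For compound 4 the expected value is 86%, with a range from 72% to 96%.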

Compound 4, a percentage reported as inhibition, at one concentration (the size of the read-out at that concentration, not a potency): 88%
The estimate for compound 4 lay 2 percentage points below the measured number; the range from low to high includes it.
By their numbers in this assay, from the lowest: compounds 1, 4, 2 and 3 (each within the scatter of the next, the first and the last beyond it).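

In this assay, replacing the nitrile-bearing ring gives a number 4 percentage points lower from compound 3 to compound 4 (within the scatter), so a nitrile is not required for a high number at this position on the sulfonyl sulfur. Taking a methyl away from the 3,4-dimethylphenyl gives a number 2 percentage points lower from compound 2 to compound 4 (within the scatter), and the 4-methylphenyl compared with the 3,5-dimethylphenyl gives a number 8 percentage points higher from compound 1 to compound 4 (within the scatter), so compound 4 cannot be told apart from any of the other three compounds, even though compound 1 and compound 3 do differ beyond the scatter. Nothing measured here offers a reason for these numbers.

From the compounds shown here alone, it remains open whether an amine or a carboxylic acid on the phenyl, or a simple alkyl chain in place of the whole ring, would keep the number this high. A reading at a single concentration also leaves open how the potencies of these four compounds compare.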